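The source may report more compounds than this note shows. Statements on the series, on what has been measured and on what is new or still open speak of the compounds shown alone.

Values in a toxicity assay on THP-1 cells (Homo sapiens) for inhibition; a lower number here means that less compound is tolerated, a higher number that more compound is tolerated:
- compound 1 `Cn1c(-c2ccc(Br)cc2)cnc1NC(=O)c1ccc(F)cc1`: 46000 nM
- compound 2 `Cc1ccccc1-c1cnc(NC(=O)c2ccc(F)cc2)n1C`: > 50000 nM (a limit, not a number)
- compound 3 `Cn1c(-c2ccc(Cl)cc2)cnc1NC(=O)c1ccc(F)cc1`: 37000 nM

Compound 3 gives 37000 nM and sits level with compound 1 within the scatter, with a 1.2-fold lower number from compound 1 to compound 3 (0.09 log units; within the scatter). Within the data shown here, no measured compound stands clearly apart from it.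

The next change leads to compound 4 `Cn1c(-c2ccc(C#N)cc2)cnc1NC(=O)c1ccc(F)cc1`: cyano in place of chloro on an aromatic carbon, para to a large group (cyano in place of chloro on an aromatic carbon). Among the measured compounds shown here, no measured step covers this swap directly. The closest is the one at the same place, a 1.2-fold lower number from compound 1 to compound 3 (0.09 log units; within the scatter). The change of the whole aryl group is also relevant, with an at least 1.0-fold higher number from compound 1 to compound 2 (0.03 log units; that floor lies within the scatter) and an at least 1.3-fold lower number from compound 2 to compound 3 (0.13 log units; that floor lies within the scatter). Neither of those floors shows a step beyond the scatter, so all three measured steps are small or unresolved.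

In this assay, no step beyond the scatter is therefore expected, and no direction can be assigned. The expected step is a 1.1-fold higher number from compound 3 to compound 4 (0.06 log units; within the scatter). Compound 4 may also read out only at the limit of > 50000 nM in this assay, at which 1 of the 3 values shown sits.

The estimated value for compound 4 is 42000 nM, with an expected range from 22000 nM to 70000 nM.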

Compound 4, half-maximal cytotoxic concentration: > 50000 nM
Compound 4: a limit, no number; the forecaster's own chance of this, stated with the estimate: 45%; at least 1.1-fold (0.07 log units) between middle value and limit.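

In this assay compound 4 gives > 50000 nM, a limit and not a number. Against the halogen compounds only floors can be read, an at least 1.3-fold higher number from compound 3 to compound 4 (0.13 log units; that floor lies within the scatter) and an at least 1.0-fold higher number from compound 1 to compound 4 (0.03 log units; that floor lies within the scatter), so nitrile in place of chloro or bromo on this aromatic carbon gives no separation beyond the scatter, and the step between compound 2 and compound 4 cannot be read. The 4-cyanophenyl group is the second aryl group in the series, after the 2-methylphenyl group, to give a limit rather than a number: the limit of > 50000 nM in this assay, at which 2 of the 4 values shown sit.

As far as these compounds go, how far compound 2 and compound 4 lie past that limit stays open. Also open, from the compounds shown here alone, is whether another group at this place, such as an amine or a carboxylic acid, would give a step beyond the scatter in this assay.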